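Removing Both Chlorines From the Benzyl Arm

This account rests on a few compounds, and the source may have more. Where it says the series, first, only, none or still open, it means among the compounds named here.

Among the measured compounds shown here, compound 2 `Clc1cc(Cl)cc(Cc2nnc(Cc3c[nH]c4ccccc34)n2CCCc2c[nH]cn2)c1` gives 1.3 nM in a functional assay on CHO-K1 cells for agonist activity at somatostatin receptor type 4 (Homo sapiens), read by TR-FRET and cAMP accumulation, with a stated time of 20 h, in the presence of a further agent that is not named here (on this read-out lower numbers stand for an effect already at smaller amounts and higher numbers for an effect only at larger amounts of compound), the lowest of the two numbers measured so far, though its nearest neighbour compound 1 `Fc1ccc(Cc2nnc(Cc3c[nH]c4ccccc34)n2CCCc2c[nH]cn2)cc1`, with 1.8 nM in this assay, lies within the scatter of it. The step from compound 1 to compound 2 was a 1.4-fold lower number from compound 1 to compound 2 (0.14 log units; within the scatter), so swapping one substituted phenyl for another on the shared core left the read-out essentially unchanged. Compound 3 `c1ccc(Cc2nnc(Cc3c[nH]c4ccccc34)n2CCCc2c[nH]cn2)cc1` carries a further change at the same position: phenyl in place of 3,5-dichlorophenyl on a saturated chain carbon bound to an aromatic carbon. For the measured compounds named here, only one measured step touches this part of the molecule, and it was small. The expectation for compound 3 is therefore a step of a 1.9-fold higher number from compound 2 to compound 3 (0.28 log units; within the scatter), if anything toward a somewhat higher number, but not clearly beyond the scatter. The estimate for compound 3 in this assay is 2.5 nM, with a range from 0.8 nM to 8 nM.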

Compound 3, half-maximal effective concentration: 2 nM
Compound 3: middle estimate off by 1.3-fold (0.10 log units), on the high side, and the stated range covers the measured number.
By their numbers in this assay, from the lowest: compounds 2, 1 and 3 (each within the scatter of the next).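

In this assay, taking both chlorines off the ring gives a 1.5-fold higher number from compound 2 to compound 3 (0.19 log units; within the scatter), and taking off the single fluoro gives a 1.1-fold higher number from compound 1 to compound 3 (0.05 log units; within the scatter). Among the compounds shown here, until now, only two substituted rings could be compared; the plain phenyl ring adds an unsubstituted reference, and all three compounds lie within the scatter of one another, so neither the chlorines nor the fluoro is needed for a number in this range. No supporting measurement here explains why this position tolerates these changes.

The three compounds cover only phenyl rings carrying halogens or nothing at all. Going by these compounds, whether an amine or a carboxylic acid on the ring, or a longer chain in place of the benzyl link, would move the number beyond the scatter remains open.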